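The source may hold more compounds than are shown below. What is called first, only, known or untested is meant among the compounds shown, and "the series" means these compounds.

Of the compounds shown here, two that share one core have been measured so far in a functional assay on K562-TAX cells (Homo sapiens), read by MTT assay, with a stated time of 3 days; on this read-out lower numbers stand for stronger inhibition and higher numbers for weaker inhibition. Compound 1 `CN(C)c1ncnc2[nH]cc(Sc3cccs3)c12` gives 22100 nM, and compound 2 `CNc1ncnc2[nH]cc(Sc3cccs3)c12` gives 21000 nM. These two values lie within the scatter of each other, so compound 2 cannot be ranked against compound 1 on these numbers.

The next compound is compound 3 `Nc1ncnc2[nH]cc(Sc3cccs3)c12`, and it comes from compound 2 through one small edit: hydrogen in place of methyl on a nitrogen on an aromatic ring. In words, this is hydrogen in place of methyl on a nitrogen on an aromatic ring, which turns methylamino into amino.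

Among the compounds with values here, only one measured step bears on this edit, because it is the same kind of replacement: a 1.1-fold lower number from compound 1 to compound 2 (0.02 log units; within the scatter). A single step is thin evidence, and this one still left a methyl on that nitrogen, whereas compound 3 has none there. Even so, the only precedent shows no change beyond the scatter, so no clear shift in either direction is expected in this assay. The estimated change is a 1.2-fold lower number from compound 2 to compound 3 (0.07 log units; within the scatter). For compound 3 the expected value is 18000 nM, with an estimated range from 7000 nM to 40000 nM.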

Compound 3, half-maximal inhibitory concentration: 17900 nM
Beside the measured number, compound 3's estimate is 1.0-fold (0.00 log units) above it; low and high end bracket the measured number.
By their numbers in this assay, from the lowest: compounds 3, 2 and 1 (each within the scatter of the next).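

In this assay the last methyl on this nitrogen goes with a 1.2-fold lower number from compound 2 to compound 3 (0.07 log units; within the scatter) as the result, and the full change of amino in place of dimethylamino gives a 1.2-fold lower number from compound 1 to compound 3 (0.09 log units; within the scatter) as its result. The earlier step still left a methyl on the nitrogen, whereas these two steps reach the bare amino, and dimethylamino, methylamino and amino all remain within the scatter of one another, so removing neither one methyl nor both separates these three compounds in this cell assay. No measurement offered here explains this flat result.

What the compounds shown leave open is whether a larger group on this nitrogen, such as an ethyl, a longer chain or an acetyl, would move the number beyond the scatter. Also open, as far as these compounds go, is what would happen with no nitrogen at all on the same aromatic carbon, for example with a methoxy or a chlorine there.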